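From phenylpiperazine to carbamoyl triazole on a shared core

The source may hold more compounds than are shown below. What is called first, only, known or untested is meant among the compounds shown, and "the series" means these compounds.

Measured so far:
compound 1, `NS(=O)(=O)c1cc(-c2nnc(CN3CCN(Cc4ccccc4)CC3)o2)c(Cl)cc1SCc1ccccc1`, gives 26000 nM in a functional assay on HCT-116 cells (Homo sapiens) for cytotoxicity, read by MTT assay, with a stated time of 72 h; on this read-out higher numbers stand for weaker inhibition and lower numbers for stronger inhibition;
compound 2, `NS(=O)(=O)c1cc(-c2nnc(CN3CCN(c4ccccc4)CC3)o2)c(Cl)cc1SCc1ccccc1`, gives 105000 nM;
compound 3, `Cc1ccc(C)c(N2CCN(Cc3nnc(-c4cc(S(N)(=O)=O)c(SCc5ccccc5)cc4Cl)o3)CC2)c1`, gives 17000 nM.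

Compound 2 has the highest number of the three: a 4.0-fold higher number from compound 1 to compound 2 (0.61 log units; beyond the scatter) and a 6.2-fold lower number from compound 2 to compound 3 (0.79 log units; beyond the scatter), both beyond the scatter. Compound 4, `NC(=O)c1cn(Cc2nnc(-c3cc(S(N)(=O)=O)c(SCc4ccccc4)cc3Cl)o2)nn1`, differs from compound 2 by 4-carbamoyl-1H-1,2,3-triazol-1-yl in place of 4-phenylpiperazin-1-yl on a saturated chain carbon bound to an aromatic carbon. The measured steps only exchange the group on the amine nitrogen in a ring of the same arm; none removes that arm, so they do not bear directly on this change, and they show only that this position tolerates shifts of modest size. The change to compound 4 is larger, so the expected step of a 2.6-fold lower number from compound 2 to compound 4 (0.42 log units; beyond the scatter) is uncertain, leaning toward a lower number because compound 2 starts from the highest value at 105000 nM. Compound 4 is estimated at 40000 nM, within 10000 nM to 150000 nM.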

Compound 4, half-maximal inhibitory concentration: 72000 nM
Beside the measured number, compound 4's estimate is 1.8-fold (0.26 log units) below it; the range from low to high includes it.
By their numbers in this assay, from the lowest: compounds 3 and 1 (each within the scatter of the next); then compounds 4 and 2 (each within the scatter of the next).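

The step (a 1.5-fold lower number from compound 2 to compound 4 (0.16 log units; within the scatter)) involves the whole arm on the saturated chain carbon, not only the group on the amine nitrogen in its ring. Here, 4-carbamoyl-1H-1,2,3-triazol-1-yl, with one five-membered aromatic ring, stands in place of 4-phenylpiperazin-1-yl, with its two six-membered rings, and the two values remain within the scatter of each other. Nothing available explains this result. Still open, on these data alone, is how a carboxylic acid in place of the carbamoyl group would read. The same applies to a simple dimethylamino group on that saturated chain carbon.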